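The compounds below may be only part of what the source reports. "The series", "measured", "known", "first", "only" and "open" are said of these compounds alone.

Measured in an in vitro ADME assay on microsomes from liver (Homo sapiens) for metabolic stability; a higher number here means faster removal of the compound, a lower number slower removal:
- Compound 1 `COc1ccc(-c2cnccn2)c2cc(C(=O)Nc3ccc(Cn4ccnc4)cc3)oc12`: < 7.84 mL/min/kg, a limit of the assay
- Compound 2 `COc1ccc(-c2cccnc2)c2cc(C(=O)Nc3ccc(Cn4ccnc4)cc3)oc12`: 53 mL/min/kg

Among the compounds with values here, compound 2, at 53 mL/min/kg, holds the only actual number in this assay so far. The entry for compound 1, < 7.84 mL/min/kg, is a limit and not a number. Placing pyridin-3-yl where pyrazin-2-yl stood gave an at least 6.7-fold higher number from compound 1 to compound 2 (0.82 log units; beyond the scatter), a step beyond the scatter.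

Compound 3 `COc1ccc(-c2ccncc2)c2cc(C(=O)Nc3ccc(Cn4ccnc4)cc3)oc12` is next, and its structural change is pyridin-4-yl in place of pyridin-3-yl on an aromatic carbon. The two compounds have the same atoms, joined differently, and the change sits on an aromatic carbon para to a methoxy group.

Within the data shown here, only one measured step bears on this place. It shows that exchanging the aromatic ring there can shift clearance widely, but it does not compare pyridin-3-yl with pyridin-4-yl, so it gives no firm direction for this change. A modest change is therefore expected, most likely within the scatter and tilted slightly downward, and the estimated step is a 1.2-fold lower number from compound 2 to compound 3 (0.07 log units; within the scatter). The wide range below is kept open by the size of that one measured step.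

For compound 3, the estimated clearance is 45 mL/min/kg, with an expected range of 18 mL/min/kg to 110 mL/min/kg.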

Compound 3, clearance: 40.7 mL/min/kg
For compound 3 the middle estimate is 1.1-fold (0.04 log units) above the measured one; the range from low to high includes it.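

In this assay, pyridin-4-yl in place of pyridin-3-yl on the aromatic carbon para to a methoxy group gave a 1.3-fold lower number from compound 2 to compound 3 (0.11 log units; within the scatter), so at this position the two pyridinyl isomers cannot be told apart on clearance. Pyridin-4-yl in place of pyrazin-2-yl gave an at least 5.1-fold higher number from compound 1 to compound 3 (0.71 log units; beyond the scatter), which shows that the large gap from pyrazin-2-yl is not confined to pyridin-3-yl but appears with both pyridinyl groups shown. The size of that gap has only a lower bound, since the entry for compound 1 is a limit and not a number: the limit of < 7.84 mL/min/kg in this assay, at which 1 of the 3 values shown sits.

The compounds shown leave open whether the gap tracks the count of ring nitrogens or belongs to pyrazin-2-yl alone, a question that a plain phenyl ring or a pyrimidin-5-yl group at this position would address. They also leave open whether the same ranking of these rings would hold if the methoxy group were replaced by an ethoxy group or a hydrogen.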